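This account rests on a few compounds, and the source may have more. Where it says the series, first, only, none or still open, it means among the compounds named here.

Measured compounds:
compound 1, `Cc1cc(=O)n(-c2cccc(F)c2)nc1C(=O)Nc1ccc(Oc2ncnc3[nH]ccc23)cc1`, 34800 nM
compound 2, `Cc1cc(=O)n(-c2ccccc2OC(F)(F)F)nc1C(=O)Nc1ccc(Oc2ncnc3[nH]ccc23)cc1`, 16200 nM
compound 3, `Cc1cc(=O)n(-c2cccc(C(F)(F)F)c2)nc1C(=O)Nc1ccc(Oc2ncnc3[nH]ccc23)cc1`, 7570 nM

In a functional assay on A549 cells (Homo sapiens) for cytotoxicity, read by MTT assay, with a stated time of 72 h (a higher number here means a weaker inhibitor, a lower number a stronger inhibitor), compound 2 gives 16200 nM and stands second highest of the three numbers; the steps of a 2.1-fold lower number from compound 2 to compound 3 (0.33 log units; beyond the scatter) and a 2.1-fold lower number from compound 1 to compound 2 (0.33 log units; beyond the scatter) place it between the other two, and the step of a 4.6-fold lower number from compound 1 to compound 3 (0.66 log units; beyond the scatter) spans the whole set. All three of these steps change only the aryl group on the aromatic nitrogen of the shared core.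

Compound 4, `Cc1cc(=O)n(-c2ccccc2OC(F)(F)F)nc1C(=O)Nc1ccc(Oc2ncnc3c2ccn3C)cc1`, differs from compound 2 elsewhere: methyl in place of hydrogen on an aromatic nitrogen. Within the data shown here, none of the measured steps touches this position, so no measured step bears directly on it, and the data give no direction for such a change. The account therefore expects for compound 4 no step beyond the scatter from compound 2, with wide uncertainty, as the estimated step of a 1.2-fold higher number from compound 2 to compound 4 (0.09 log units; within the scatter). Compound 4 is thus estimated at 20000 nM in this assay, within the range 6000 nM to 70000 nM.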

Compound 4, half-maximal inhibitory concentration: 25200 nM
Compound 4: the middle estimate sits 1.3-fold (0.10 log units) below what was measured; the range from low to high includes it.
By their numbers in this assay, from the lowest: compound 3; then compounds 2, 4 and 1 (each within the scatter of the next, the first and the last beyond it).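

In this assay, among these compounds, methyl in place of hydrogen on an aromatic nitrogen of the five-membered aromatic ring gives the first reading at this position (a 1.6-fold higher number from compound 2 to compound 4 (0.19 log units; within the scatter)), where the earlier compounds had varied only the aryl group. With the 2-(trifluoromethoxy)phenyl group held constant, this added carbon therefore leaves the number within the scatter, so this single step shows no measurable gain or loss from capping that nitrogen with methyl. Nothing available here offers an explanation for this result.

The compounds shown leave open whether a longer chain, or a chain carrying an amine or a carboxylic acid, would behave as methyl does on this nitrogen. They also leave open whether methyl gives the same result alongside the 3-(trifluoromethyl)phenyl group of compound 3.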